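The compounds below may be only part of what the source reports. "The series", "measured", "known", "first", "only" and "open" are said of these compounds alone.

Compound 1 `O=C(CCCCCC(=O)Nc1ccc(O)c(C(=O)Nc2ccc(F)c(Cl)c2)c1)NO` in a functional assay on HL-60 cells (Homo sapiens) for antiproliferative activity, read by MTT assay, with a stated time of 48 h (on this read-out higher numbers stand for weaker inhibition and lower numbers for stronger inhibition), gives only a limit of the assay, > 100000 nM. Compound 2 `COc1cc(O)c(C(=O)Nc2ccc(F)c(Cl)c2)cc1NC(=O)CCCCCC(=O)NO` in this assay gives 9830 nM. Compound 3 `C#Cc1cccc(NC(=O)c2cccc(NC(=O)CCCCCC(=O)NO)c2)c1` in this assay gives only a limit of the assay, > 100000 nM.

The change methoxy in place of hydrogen on an aromatic carbon produced a step of an at least 10-fold lower number from compound 1 to compound 2 (1.00 log units; beyond the scatter). Compound 4 `C#Cc1cccc(NC(=O)c2cc(NC(=O)CCCCCC(=O)NO)ccc2OC)c1` carries the same kind of change on the core of compound 3, (methoxy in place of hydrogen on an aromatic carbon); the place is not identical, since in compound 1 the site is also meta to a hydroxy group, which the place in compound 3 lacks. The difference between the two cores is not broken down here. The true size of the first step is uncertain because two values sit at the limit of > 100000 nM in this assay, at which 2 of the 3 values shown sit. For compound 4 a step of about an at least 6.6-fold lower number from compound 3 to compound 4 (0.82 log units; beyond the scatter) is expected, because the same kind of change earlier gave an at least 10-fold lower number from compound 1 to compound 2 (1.00 log units; beyond the scatter). Compound 4 is therefore estimated in this assay at 15000 nM, between 3000 nM and 100000 nM.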

Compound 4, half-maximal inhibitory concentration: 7100 nM
For compound 4 the middle estimate is 2.1-fold (0.32 log units) above the measured one; low and high end bracket the measured number.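

In this assay, methoxy in place of hydrogen on an aromatic carbon again gave a step beyond the scatter, an at least 14-fold lower number from compound 3 to compound 4 (1.14 log units; beyond the scatter), so on both cores shown the change goes with a lower number. Whether the change is worth the same on the two cores stays undecided: the same change on two cores in this assay, an at least 10-fold lower number (1.00 log units; beyond the scatter) from compound 1 to compound 2 and an at least 14-fold lower number (1.14 log units; beyond the scatter) from compound 3 to compound 4; the limit leaves it open whether they differ. Both steps start from a limit, so neither gives a true size, and two cores do not establish a rule for the whole series: the limit of > 100000 nM in this assay, at which 2 of the 4 values shown sit.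

The compounds shown leave open what ethoxy, chlorine or an amine would do at the same place. Also open, going by these compounds, is whether the methoxy step would persist with a longer chain in place of the one shared by all four compounds.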